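The compounds below may be only part of what the source reports. "The series", "measured", "known", "first", "only" and "open" are said of these compounds alone.

Three compounds share one core and differ only in the group on the amide nitrogen. In an assay on isolated protein for inhibition of NEDD8-activating enzyme E1 regulatory subunit (Homo sapiens), read by Western blot, with stated times of 10 min and 30 min, tested at 25 uM (a lower number here means less inhibition, a higher number more inhibition at the concentration tested (going by the name of the read-out)), compound 1 `CCOc1nc2cccc(C(=O)NCCCN(C)C)c2n1Cc1ccc(-c2ccccc2-c2nnn[nH]2)cc1` gives 29.5%; compound 2 `CCOc1nc2cccc(C(=O)N[C@H]3CC[C@H](C(=O)OC)CC3)c2n1Cc1ccc(-c2ccccc2-c2nnn[nH]2)cc1` gives 28.6%; compound 3 `CCOc1nc2cccc(C(=O)Nc3ccccc3)c2n1Cc1ccc(-c2ccccc2-c2nnn[nH]2)cc1` gives 34.6%. Compound 3 holds the highest of the three numbers, yet every step, a number 0.9 percentage points lower from compound 1 to compound 2 (within the scatter), a number 5.1 percentage points higher from compound 1 to compound 3 (within the scatter) and a number 6 percentage points higher from compound 2 to compound 3 (within the scatter), stays within the scatter, so none of the three stands apart. Going by the values given here, compound 4 `CCOc1nc2cccc(C(=O)Nc3ccc(OC)cc3)c2n1Cc1ccc(-c2ccccc2-c2nnn[nH]2)cc1` arises from compound 3 by methoxy in place of hydrogen on an aromatic carbon, a change no measured step mirrors. Since swapping whole amide substituents moved the inhibition so little, the expected step is a number 0.6 percentage points lower from compound 3 to compound 4 (within the scatter), nothing beyond the scatter. For compound 4 the estimated inhibition is 34%, within 24% to 44%.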

Compound 4, a percentage reported as inhibition, at one concentration (the size of the read-out at that concentration, not a potency): 25.8%
Compound 4: middle estimate off by 8.2 percentage points, on the high side, and the stated range covers the measured number.
By their numbers in this assay, from the lowest: compounds 4, 2, 1 and 3 (each within the scatter of the next).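

In this assay, going by these compounds alone, methoxy on an aromatic carbon of the phenyl group is the first change to that ring rather than a swap of the whole amide substituent, and it gives a number 8.8 percentage points lower from compound 3 to compound 4 (within the scatter). The 4-methoxyphenyl group also stays level with the two non-aromatic substituents, at a number 3.7 percentage points lower from compound 1 to compound 4 (within the scatter) and a number 2.8 percentage points lower from compound 2 to compound 4 (within the scatter), so this position has not yet separated any compounds. No evidence on hand bears on this result. The compounds shown leave open whether an amine or a carboxylic acid on that aromatic carbon would move the inhibition beyond the scatter.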